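A few compounds are considered here, and "the series" means these few. Any claim that something is new, unique, unknown or untested is made for them only; others in the source may bear on it.

Measured compounds:
- compound 1, `NC(=O)/C=C1\CCc2ccc(Cl)cc21`, in a functional assay on the whole organism with Mus musculus as the target, in the rotarod test (on this read-out higher numbers stand for an effect only at larger amounts of compound and lower numbers for an effect already at smaller amounts), gives 221 mg/kg
- compound 2, `O=C(/C=C1\CCc2cc(F)ccc21)NC1CC1`, in this assay gives 193 mg/kg
- compound 3, `NC(=O)/C=C1/CCc2ccc(F)cc21`, in this assay gives 92 mg/kg

Among these three numbers compound 2 holds the second highest. Its nearest neighbour is compound 1, whose slightly higher number lies within the scatter, so the two cannot be told apart. Compound 3 gives a lower number, and that gap lies beyond the scatter.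

The unmeasured compound 4, `NC(=O)/C=C1\CCc2cc(F)ccc21`, differs from compound 2 in one place: hydrogen in place of cyclopropyl on an amide-type nitrogen. The shared core and the fluorine of compound 2 are kept. For the measured compounds named here, no measured pair here shows this change on its own, so its effect has to be judged from the whole set.

Because compound 1 gives 221 mg/kg and compound 3 gives 92 mg/kg, both of them carrying the hydrogen on the amide nitrogen and their values standing on either side of compound 2, the change is expected to move the number little, probably not beyond the scatter, with a slight lean towards a lower number. The step of a 1.3-fold lower number from compound 2 to compound 4 (0.11 log units; within the scatter) is therefore expected to be small. Compound 4 is estimated at 150 mg/kg, within a range of 70 mg/kg to 320 mg/kg.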

Compound 4, dose for half-maximal effect: > 100 mg/kg
Compound 4 ended at the assay's limit (the forecaster's own chance of this, stated with the estimate: 5%); the middle value lies beyond the limit too.
By their numbers in this assay, from the lowest: compound 3; then compounds 2 and 1 (each within the scatter of the next).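

In this assay compound 4 gives > 100 mg/kg, which is a limit of the assay and not a number. For the compounds shown here, no step from compound 2 to compound 4 can be read from this result. The compounds shown leave open how far hydrogen in place of cyclopropyl on the amide-type nitrogen moves the number.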